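The source may hold more compounds than are shown below. What is called first, only, known or untested is meant among the compounds shown, and "the series" means these compounds.

In a functional assay on CCRF-CEM cells (Homo sapiens), read by MTT assay, with a stated time of 72 h; on this read-out higher numbers stand for weaker inhibition and lower numbers for stronger inhibition:
- compound 1 `CSc1ncnc2c1c(-c1cccs1)cn2[C@@H]1O[C@H](CO)[C@@H](O)[C@H]1O`: > 20000 nM
- compound 2 `CNc1ncnc2c1c(-c1ccco1)cn2[C@@H]1O[C@H](CO)[C@@H](O)[C@H]1O`: 180 nM

Compound 1 has the entry > 20000 nM, which is a limit of the assay and not a number.

Among the measured compounds shown here, compound 2 carries the only actual number so far, 180 nM. For the measured compounds named here, the two compounds differ in more than one place, so their values give no measured step for any single change.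

The next compound is compound 3 `C#Cc1cn([C@@H]2O[C@H](CO)[C@@H](O)[C@H]2O)c2ncnc(NC)c12`, not yet measured. Its difference from compound 2 is ethynyl in place of furan-2-yl on an aromatic carbon, on the five-membered aromatic ring with 1 nitrogen.

Going by the values given here, no measured step covers this exchange, so the expectation rests on compound 2 at 180 nM and remains loose. In this assay, the expected step of a 1.4-fold higher number from compound 2 to compound 3 (0.14 log units; within the scatter) stays within the usual scatter, with a slight lean towards weaker inhibition. A much larger move in either direction cannot be excluded.

For compound 3 the estimated value is 250 nM, with an expected range of 30 nM to 3000 nM.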

Compound 3, half-maximal inhibitory concentration: > 20000 nM
Compound 3 gave a limit, no number (the forecaster's own chance of this, stated with the estimate: 12%); middle value at least 80-fold (1.90 log units) away from the limit.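

In this assay, among the compounds shown here, ethynyl in place of furan-2-yl on this aromatic carbon gives an at least 110-fold higher number from compound 2 to compound 3 (2.04 log units; beyond the scatter), the first measured step and one that lies far beyond the scatter. The entry for compound 3, > 20000 nM, is a limit of the assay and not a number, so the step gives only a lower bound on the true size of the change. With the rest of the molecule unchanged, this position is thus shown to be highly sensitive to the group it carries, and a reading at the limit is the more common outcome in the series so far: the limit of > 20000 nM in this assay, at which 2 of the 3 values shown sit.

On these data alone, whether a measurable value at this position depends on a five-membered aromatic ring as such remains open, as does the outcome with a phenyl ring, a longer chain such as prop-1-ynyl, or an amine. Compound 1 differs from both compound 2 and compound 3 in more than one place, so no step can be read from it, and the separate contributions of its groups stay unresolved.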